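From Acetyl to Dimethylcarbamoyl on a Shared Core

The source may hold more compounds than are shown below. What is called first, only, known or untested is meant among the compounds shown, and "the series" means these compounds.

In a functional assay on Huh-5-2 cells (Homo sapiens), read by MTT assay (on this read-out lower numbers stand for higher toxicity in this test and higher numbers for lower toxicity in this test), compound 1 `O=C(O)c1ccc2c(c1)nc(-c1ccc(OCc3cc(Cl)ccc3-c3cccc(Cl)c3)cc1)n2C1CCCCC1` reads 32000 nM and compound 2 `CC(=O)c1ccc(-c2ccc(Cl)cc2)c(COc2ccc(-c3nc4cc(C(=O)O)ccc4n3C3CCCCC3)cc2)c1` reads 24000 nM as a number within the usual scatter of the other. Compound 3 `CN(C)C(=O)c1ccc(-c2ccc(Cl)cc2)c(COc2ccc(-c3nc4cc(C(=O)O)ccc4n3C3CCCCC3)cc2)c1` differs from compound 2 by dimethylamino in place of methyl on a carbonyl carbon with dimethylamino in place of methyl on a carbonyl carbon, which turns acetyl into dimethylcarbamoyl. For the measured compounds named here, no measured pair shows this change, so the data offer no direct guide. The expected 1.1-fold higher number from compound 2 to compound 3 (0.03 log units; within the scatter) in this assay is no step beyond the scatter, in neither direction. Compound 3 is estimated to read 26000 nM with an expected range of 12000 nM to 50000 nM in a repeat measurement.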

Compound 3, half-maximal cytotoxic concentration: 28000 nM
Beside the measured number, compound 3's estimate is 1.1-fold (0.03 log units) below it, within the range that was stated.
By their numbers in this assay, from the lowest: compounds 2, 3 and 1 (each within the scatter of the next).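

In this assay, for the compounds shown here, the change of acetyl into dimethylcarbamoyl gives a 1.2-fold higher number from compound 2 to compound 3 (0.07 log units; within the scatter), the first direct reading of this swap on the shared core. At this position, dimethylamino can take the place of methyl on the carbonyl carbon without the number moving beyond the scatter. Nothing measured here explains this result. Still open, going by these compounds, is whether a carboxylic acid or a morpholine amide at the same place would also stay within the scatter. This single step also cannot show whether the swap behaves the same way on a different core.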